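This account rests on a few compounds, and the source may have more. Where it says the series, first, only, none or still open, it means among the compounds named here.

Compound 1 `CCCCNc1nc(N)nc2c1CN(S(C)(=O)=O)CC2` and compound 2 `CCCCNc1nc(N)nc2c1CN(C(=O)c1cnccn1)CC2` share the same core and differ only in the group carried on the amine nitrogen in the ring. In an assay on HEK293 cells for agonist activity at Toll-like receptor 8 (Homo sapiens), read by a luciferase reporter, with a stated time of 6 h (on this read-out higher numbers stand for an effect only at larger amounts of compound and lower numbers for an effect already at smaller amounts), compound 1 gives 9.9 uM. Compound 2, which carries a (pyrazin-2-yl)carbonyl in place of the methylsulfonyl, gives 2.2 uM in this assay. For the measured compounds named here, that change produced a 4.5-fold lower number from compound 1 to compound 2 (0.65 log units; beyond the scatter), so compound 2 stands at the lowest of the two numbers recorded so far, with compound 1 as its only neighbour.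

Compound 3 `CCCCNc1nc(N)nc2c1CN(C(=O)c1scnc1C)CC2` keeps the carbonyl on that ring nitrogen but swaps the aromatic ring attached to it: 4-methyl-1,3-thiazol-5-yl in place of pyrazin-2-yl on a carbonyl carbon. Going by the values given here, the one measured step, from compound 1 to compound 2, exchanged a methylsulfonyl for an aromatic carbonyl group at this same nitrogen and was modest in size. The step to compound 3 is a smaller one in kind, since a six-membered aromatic ring gives way to a five-membered one with the same count of heavy atoms and hydrogen-bond acceptors. The expectation for compound 3 in this assay is therefore a number close to that of compound 2, with a 1.1-fold higher number from compound 2 to compound 3 (0.06 log units; within the scatter) as the estimated step. Compound 3 is estimated at 2.5 uM, within a range from 0.8 uM to 8 uM.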

Compound 3, minimum effective concentration: 5.6 uM
Compound 3: the middle estimate sits 2.2-fold (0.35 log units) below what was measured; low and high end bracket the measured number.
By their numbers in this assay, from the lowest: compound 2; then compounds 3 and 1 (each within the scatter of the next).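

With the carbonyl kept on the ring nitrogen, the aromatic ring attached to it still matters: 4-methyl-1,3-thiazol-5-yl in place of pyrazin-2-yl gives a 2.5-fold higher number from compound 2 to compound 3 (0.41 log units; beyond the scatter) in this assay even though both groups count the same number of heavy atoms and hydrogen-bond acceptors. An aromatic carbonyl group at this nitrogen is also not enough on its own to set a compound apart from the methylsulfonyl one, since a 1.8-fold lower number from compound 1 to compound 3 (0.25 log units; within the scatter) cannot be told from repeat scatter, whereas the step from methylsulfonyl to (pyrazin-2-yl)carbonyl lay beyond it. Nothing measured here explains why these two aromatic groups differ.

As far as these compounds go, a 1,3-thiazol-5-yl group without the methyl, or a plain phenyl ring on the same carbonyl, would be needed to separate the part played by the methyl from that of the change in ring, so this remains open. Also open, from the compounds shown here alone, is how a non-aromatic acyl group such as acetyl, or a carbonyl carrying an amine, would compare at this nitrogen.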